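Changing the Amine Tail of Compound 1

This account rests on a few compounds, and the source may have more. Where it says the series, first, only, none or still open, it means among the compounds named here.

Measured so far:
compound 1, `CCN(CC)CCCOc1ccc2cc(NC(=O)c3ccc(O)c(CC=C(C)C)c3)c(=O)oc2c1C`, gives 4900 nM
compound 2, `CC(C)=CCc1cc(C(=O)Nc2cc3ccc(OCCCNC(C)(C)C)c(C)c3oc2=O)ccc1O`, gives 660 nM
compound 3, `CC(C)=CCc1cc(C(=O)Nc2cc3ccc(OCCCN(C)C(C)(C)C)c(C)c3oc2=O)ccc1O`, gives 880 nM

In a functional assay on SK-BR-3 cells (Homo sapiens) for antiproliferative activity (a higher number here means a weaker inhibitor, a lower number a stronger inhibitor), compound 1 holds the highest of the three numbers and is therefore the weakest inhibitor of the set; compound 3 stands nearest to it and compound 2 furthest away. Compound 4, `CC(C)=CCc1cc(C(=O)Nc2cc3ccc(OCCCNCCO)c(C)c3oc2=O)ccc1O`, has not yet been measured. It differs from compound 1 in a single place: (2-hydroxyethyl)amino in place of diethylamino on a saturated chain carbon, three bonds along the chain from an oxygen on an aromatic ring.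

Two of the measured steps start from the same diethylamino group at the same place. a 7.4-fold lower number from compound 1 to compound 2 (0.87 log units; beyond the scatter) and a 5.6-fold lower number from compound 1 to compound 3 (0.75 log units; beyond the scatter) show that exchanging this group for a tert-butyl-bearing amine lowered the number clearly in both cases, while the further exchange a 1.3-fold higher number from compound 2 to compound 3 (0.12 log units; within the scatter) made no clear difference. Among the compounds with values here, the (2-hydroxyethyl)amino group entering in compound 4 is a different kind of amine from either of those, so the earlier steps give only a rough guide: a change at this position can move the number, and so far it has moved it downward. A modest drop, smaller than either measured one, seems the most reasonable expectation, with a wide range to allow for no change at all.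

Compound 4 is expected to give about 2000 nM, somewhere between 700 nM and 6000 nM, which would mean a 2.5-fold lower number from compound 1 to compound 4 (0.39 log units; beyond the scatter).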

Compound 4, half-maximal inhibitory concentration: 610 nM
The estimate for compound 4 lay 3.3-fold (0.52 log units) above the measured number; measured number outside the range, below it.
By their numbers in this assay, from the lowest: compounds 4, 2 and 3 (each within the scatter of the next); then compound 1.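

In this assay, the step of an 8.0-fold lower number from compound 1 to compound 4 (0.90 log units; beyond the scatter) shows that the gain at this position does not depend on a tert-butyl group, since (2-hydroxyethyl)amino, an amine of a different kind, also leaves diethylamino well behind. The new compound also lands level with both tert-butyl amines, with a 1.1-fold lower number from compound 2 to compound 4 (0.03 log units; within the scatter) and a 1.4-fold lower number from compound 3 to compound 4 (0.16 log units; within the scatter), so exchanging tert-butyl for 2-hydroxyethyl on the amine nitrogen makes no clear difference here, and among the compounds shown only the diethylamino compound stands apart. Why diethylamino differs from the other three amines cannot be said, as no supporting data bear on this result.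

The compounds shown leave open whether the hydroxyl oxygen of the 2-hydroxyethyl group matters at all, a question that a simple ethylamino or a (2-methoxyethyl)amino tail would address. They also leave open how much further this tail can change, for instance to a 3-hydroxypropyl group on the nitrogen or to a carboxylic acid at the end of the chain, before the number rises again.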